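Extending a Pyrrole Arm by a Phenyl Ring

The source may hold more compounds than are shown below. What is called first, only, known or untested is meant among the compounds shown, and "the series" means these compounds.

Compound 1 `Cn1cncc1CN1CC(N(CCn2cccc2)S(=O)(=O)c2ccccn2)Cc2cc(C#N)ccc21` is the starting point. In an ADME assay on Caco-2 cells (Homo sapiens) for permeability, in the apical to basolateral direction (on this read-out lower numbers stand for lower permeability and higher numbers for higher permeability), compound 1 gives 12.4 10^-6 cm/s, the highest of the three numbers recorded. Compound 2 `Cn1cncc1CN1CC(N(CC2CCN(C(=O)NC(C)(C)C)CC2)S(=O)(=O)c2ccccn2)Cc2cc(C#N)ccc21` gives 0.6 10^-6 cm/s, and compound 3 `Cn1cncc1CN1CC(N(CC2CCN(C(=O)c3ccco3)CC2)S(=O)(=O)c2ccccn2)Cc2cc(C#N)ccc21` gives 0.5 10^-6 cm/s, both far from compound 1 and close to each other. Within the data shown here, the only step measured between two compounds that differ in one place is a 1.2-fold lower number from compound 2 to compound 3 (0.08 log units; within the scatter), a change at a carbonyl carbon that has nothing in common with the change studied here.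

Compound 4 `Cn1cncc1CN1CC(N(Cc2cccc(-n3cccc3)c2)S(=O)(=O)c2ccccn2)Cc2cc(C#N)ccc21` differs from compound 1 as follows: 3-(1H-pyrrol-1-yl)phenyl in place of (1H-pyrrol-1-yl)methyl on a saturated chain carbon bound to a sulfonamide nitrogen. Among the measured compounds shown here, no measured step touches this position, so the expectation rests on compound 1 alone and on the absence of a guiding precedent. Compound 4 is therefore expected to stay near compound 1, with a 1.2-fold lower number from compound 1 to compound 4 (0.09 log units; within the scatter) as the expected step, not clearly beyond the scatter. The estimate for compound 4 in this assay is 10 10^-6 cm/s, with a range from 4 10^-6 cm/s to 25 10^-6 cm/s.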

Compound 4, apparent permeability: 2.3 10^-6 cm/s
Beside the measured number, compound 4's estimate is 4.3-fold (0.64 log units) above it; the measured number lies below the stated range.
By their numbers in this assay, from the lowest: compounds 3 and 2 (each within the scatter of the next); then compound 4; then compound 1.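

The number in this assay responds to the group on this saturated chain carbon bound to a sulfonamide nitrogen: 3-(1H-pyrrol-1-yl)phenyl in place of (1H-pyrrol-1-yl)methyl gives a 5.4-fold lower number from compound 1 to compound 4 (0.73 log units; beyond the scatter). The five-membered aromatic ring and the hydrogen-bond donor and acceptor counts stay the same, so the visible differences are the added six-membered aromatic ring of carbon only and the larger heavy-atom count. No measurement here explains the lower number.

A single step cannot separate the effect of the added ring from that of the change in the arm's overall shape and length. Still open, as far as these compounds go, is where a plain benzyl group, a 3-(1H-pyrrol-1-yl)propyl chain or a phenyl ring carrying an amine or a carboxylic acid would fall in this assay.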